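The source may report more compounds than this note shows. Statements on the series, on what has been measured and on what is new or still open speak of the compounds shown alone.

Working notes on the series.

Compound 1 `COc1cc(/C=N/Nc2nc(-c3cccc(Br)c3)cs2)cc(Br)c1OC` carries a single bromine on the benzylidene ring and another on the pendant aryl ring. Among the compounds with values here, in a functional assay on HepG2 cells (Homo sapiens) for inhibition, read by MTT assay, with a stated time of 48 h (a higher number here means a weaker inhibitor, a lower number a stronger inhibitor), compound 1 gives 66200 nM, the only plain number so far in the set. Compound 2 `COc1cc(/C=N/Nc2nc(-c3cccc(Br)c3)cs2)c(Br)c(Br)c1OC` adds a second bromine to the benzylidene ring. In this assay compound 2 reaches only > 100000 nM, which is a limit of the assay rather than a number. The step of an at least 1.5-fold higher number from compound 1 to compound 2 (0.17 log units; that floor lies within the scatter) is therefore only a floor, and that floor lies within the scatter (the limit of > 100000 nM in this assay, at which 1 of the 2 values shown sits).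

Compound 3 `COc1cc(/C=N/Nc2nc(-c3ccccc3)cs2)cc(Br)c1OC` is to be measured. Against compound 1 the change is hydrogen in place of bromo on an aromatic carbon. Within the data shown here, no measured step touches this ring; the one step known removes nothing and adds a bromo elsewhere, so it gives no direction here. For this assay the expectation for compound 3 is a step of a 1.1-fold higher number from compound 1 to compound 3 (0.05 log units; within the scatter), within the scatter. Compound 3 is thus estimated at 75000 nM, between 35000 nM and 160000 nM.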

Compound 3, half-maximal inhibitory concentration: 68300 nM
Compound 3: middle estimate off by 1.1-fold (0.04 log units), on the high side; the range from low to high includes it.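

The change from 3-bromophenyl to phenyl gives, in this assay, a 1.0-fold higher number from compound 1 to compound 3 (0.01 log units; within the scatter). Within the data shown here, this is the first reading at the pendant ring: at this position, on the shared core, bromo and hydrogen cannot be told apart in this assay, whereas the earlier step concerned the benzylidene ring and gave only a floor. Compound 2 remains a limit of the assay and not a number, and no step shown so far lies beyond the scatter: the limit of > 100000 nM in this assay, at which 1 of the 3 values shown sits.

Open, as far as these compounds go, is whether a group of another kind at this position, such as an amine or a carboxylic acid, would move the number beyond the scatter. Also open, from the compounds shown here alone, is what hydrogen in place of the bromo on the benzylidene ring of compound 1 would do.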